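This account rests on a few compounds, and the source may have more. Where it says the series, first, only, none or still open, it means among the compounds named here.

Of the compounds shown here, three sharing one core have been measured in an assay on brain for displacement of a labelled ligand from Neuronal acetylcholine receptor; alpha4/beta2 (Rattus norvegicus); on this read-out higher numbers stand for weaker inhibition and lower numbers for stronger inhibition. Compound 1 `Cc1ccc(OCC2(N)CC2)cn1` gives 266 nM. Compound 2 `CNC1(COc2ccc(Cl)nc2)CC1` gives 13 nM. Compound 3 `CN(C)C1(COc2ccc(Cl)nc2)CC1` gives 304 nM. For the measured compounds named here, compound 3 stands at the high end of these three numbers: its gap to compound 1 lies within the scatter, while its gap to compound 2 is the one single-point step in the set, a 23-fold higher number from compound 2 to compound 3 (1.37 log units; beyond the scatter), a large rise that came with methyl in place of hydrogen on an amine nitrogen.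

Compound 4 `NC1(COc2ccc(Cl)nc2)CC1` differs from compound 3 by amino in place of dimethylamino on a saturated ring carbon. The step from compound 2 to compound 3 is the only one that bears on this change, and it runs the other way: stripping methyl from the amine nitrogen moved the number down sharply. Going by the values given here, compound 1, which also carries an amino group on the same ring carbon, sits near compound 3, but it differs from compound 4 elsewhere, so its value gives no step here. Compound 4 is therefore expected to show a lower number, roughly a 7.6-fold lower number from compound 3 to compound 4 (0.88 log units; beyond the scatter), with an estimated 40 nM in this assay, between 8 nM and 200 nM.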

Compound 4, inhibition constant: 98 nM
The estimate for compound 4 lay 2.5-fold (0.39 log units) below the measured number, and the stated range covers the measured number.
By their numbers in this assay, from the lowest: compound 2; then compound 4; then compounds 1 and 3 (each within the scatter of the next).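

In this assay, for the compounds shown here, the amine nitrogen on the saturated ring carbon can now be read in three forms, and the number does not move in one direction with the count of methyl groups: amino in place of dimethylamino lowers it (a 3.1-fold lower number from compound 3 to compound 4 (0.49 log units; beyond the scatter)), whereas hydrogen in place of methyl raises it (a 7.5-fold higher number from compound 2 to compound 4 (0.88 log units; beyond the scatter)), which leaves the single methyl of compound 2 with the lowest number of the three. Going by these compounds alone, the result also gives a first reading at the aromatic carbon with the amino group held constant, where chloro in place of methyl lowers the number (a 2.7-fold lower number from compound 1 to compound 4 (0.43 log units; beyond the scatter)). Nothing available explains either shift.

As far as these compounds go, whether an ethyl or cyclopropyl group on the amine nitrogen would keep the low number of compound 2 remains open. So does whether a fluoro or bromo group on the aromatic carbon would follow chloro, and whether the same order of the three amines would hold with methyl there.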